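Three reported limits and a phenoxy analogue still to test

The source may report more compounds than this note shows. Statements on the series, on what has been measured and on what is new or still open speak of the compounds shown alone.

Compound 1, `COc1cc2c(cc1OC)CN(S(=O)(=O)c1ccc(-n3cc(COc4ccc([N+](=O)[O-])cc4)nn3)cc1)CC2`, in a functional assay on MOLT-3 cells (Homo sapiens) for cytotoxicity, read by MTT assay, with a stated time of 48 h (a higher number here means a weaker inhibitor, a lower number a stronger inhibitor), gives > 50 ug/mL, which is a limit of the assay.
Compound 2, `COc1cc2c(cc1OC)CN(S(=O)(=O)c1ccc(-n3cc(COc4ccc(C)cc4)nn3)cc1)CC2`, in this assay gives > 50 ug/mL, again a limit.
Compound 3, `COc1cc2c(cc1OC)CN(S(=O)(=O)c1ccc(-n3cc(COc4ccccc4C)nn3)cc1)CC2`, in this assay gives > 50 ug/mL, also a limit.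

Among the compounds with values here, compound 3 thus stands where every value in this set stands, at the limit of > 50 ug/mL in this assay, at which 3 of the 3 values shown sit, and no compound is ranked against another. Compound 4, `COc1cc2c(cc1OC)CN(S(=O)(=O)c1ccc(-n3cc(COc4ccccc4)nn3)cc1)CC2`, differs from compound 3 by hydrogen in place of methyl on an aromatic carbon. The measured steps a step that the two limits leave unreadable from compound 1 to compound 2, a step that the two limits leave unreadable from compound 1 to compound 3 and a step that the two limits leave unreadable from compound 2 to compound 3 are all unreadable, so no size can be carried over. Compound 4 is therefore expected to give another limit, with an expected step of a number no higher from compound 3 to compound 4 (the limit leaves the size open) in this assay. Compound 4 is estimated at 50 ug/mL, within 25 ug/mL to 100 ug/mL.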

Compound 4, half-maximal inhibitory concentration: > 50 ug/mL
Compound 4: only a limit was reported; the forecaster's own chance of this, stated with the estimate: 85%; the middle value lies on the limit itself.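

Compound 4 also gives only a limit, and the steps to it from compound 1, compound 2 and compound 3 cannot be read. The compounds shown leave open whether methyl, nitro and hydrogen on that aromatic ring differ at all, as every value remains a limit: the limit of > 50 ug/mL in this assay, at which 4 of the 4 values shown sit.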